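A Benzyl Sulfone Replaces an Ethyl Sulfone

A few compounds are considered here, and "the series" means these few. Any claim that something is new, unique, unknown or untested is made for them only; others in the source may bear on it.

Three compounds that share one core were tested in a functional assay on MDA-MB-231 cells (Homo sapiens) for antiproliferative activity, read by MTT assay, with a stated time of 24 h; on this read-out lower numbers stand for stronger inhibition and higher numbers for weaker inhibition. Compound 1 `CCCCSc1nnc(COc2cc(C)c3c(C)cc(=O)oc3c2)o1` carries a butylsulfanyl group on an aromatic carbon of that core; in this assay compound 1 gives > 100000 nM, which is a limit of the assay and not a number. Compound 2 `CCCCCCSc1nnc(COc2cc(C)c3c(C)cc(=O)oc3c2)o1` carries a hexylsulfanyl group on that aromatic carbon, and in this assay compound 2 gives > 100000 nM, again a limit. Compound 3 `CCS(=O)(=O)c1nnc(COc2cc(C)c3c(C)cc(=O)oc3c2)o1` carries an ethylsulfonyl group there, and in this assay compound 3 gives > 100000 nM, once more a limit. The steps between the three cannot be sized: a step that the two limits leave unreadable from compound 1 to compound 2, a step that the two limits leave unreadable from compound 1 to compound 3 and a step that the two limits leave unreadable from compound 2 to compound 3. Compound 3 thus stands where both others stand, namely (the limit of > 100000 nM in this assay, at which 3 of the 3 values shown sit).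

Compound 4 `Cc1cc(OCc2nnc(S(=O)(=O)Cc3cccc(F)c3)o2)cc2oc(=O)cc(C)c12` differs from compound 3 by 3-fluorophenyl in place of methyl on a saturated chain carbon bound to a sulfonyl sulfur. Going by the values given here, no measured step is readable, so none can be carried over to this change; the only guide is that every compound so far sits at the limit. The step from compound 3 to compound 4 is therefore expected to be small, an at least 1.2-fold lower number from compound 3 to compound 4 (0.09 log units; that floor lies within the scatter), and may again end at the limit. Compound 4 is expected to give about 80000 nM, within a range from 15000 nM to 200000 nM.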

Compound 4, half-maximal inhibitory concentration: 21300 nM
Compound 4: middle estimate off by 3.8-fold (0.57 log units), on the high side; measured number inside the range.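

In this assay, going by these compounds alone, the change of ethyl to 3-fluorobenzyl is the first one whose effect can be read at all, and it gives an at least 4.6-fold lower number from compound 3 to compound 4 (0.67 log units; beyond the scatter). So a group on a saturated chain carbon bound to a sulfonyl sulfur can shift this read-out, and a six-membered aromatic ring of carbon only, with its fluorine, is accepted there in place of methyl, although the measured number still lies in a weak range of the scale. Compound 4 is also the only compound shown that moves away from the limit, which gives the series its first real number to compare against: the limit of > 100000 nM in this assay, at which 3 of the 4 values shown sit.

With a ring and a fluorine entering together, this single step cannot tell which of them carries the gain, and a plain benzyl group or a 3-chlorobenzyl group on the sulfonyl sulfur would begin to separate the two. On these data alone, it also remains open whether the sulfonyl link itself matters, which a 3-fluorobenzylsulfanyl group on the same aromatic carbon of the shared core would test.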